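Branching on the ring-nitrogen substituent and affinity

The source may hold more compounds than are shown below. What is called first, only, known or untested is meant among the compounds shown, and "the series" means these compounds.

Compound 1: `CCc1nc2c(-c3ccc(Cl)cc3Cl)ccnc2n1[C@@H](CC)C1CC1`, 0.4 nM
Compound 2: `CCc1nc2c(-c3ccc(Cl)cc3Cl)ccnc2n1C(C)CC`, 1.3 nM

In an assay for binding affinity to Corticotropin releasing factor receptor (Rattus norvegicus) (on this read-out lower numbers stand for stronger inhibition and higher numbers for weaker inhibition), compound 2 gives the higher of the two numbers; the one step shown, a 3.3-fold higher number from compound 1 to compound 2 (0.51 log units; beyond the scatter), separates it from compound 1. Compound 3, `CCc1nc2c(-c3ccc(Cl)cc3Cl)ccnc2n1C(CC)CC`, is not yet measured. It differs from compound 2 by methyl in place of hydrogen on a saturated chain carbon, two bonds along the chain from an aromatic nitrogen. Going by the values given here, only the step from compound 1 to compound 2 bears on this change, and it was modest; since a larger branched group there gave the lower number, a small shift downward in this assay is expected for compound 3, roughly a 1.9-fold lower number from compound 2 to compound 3 (0.27 log units; within the scatter). The estimate for compound 3 is 0.7 nM, within 0.3 nM to 2 nM.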

Compound 3, inhibition constant: 1 nM
Compound 3: the middle estimate sits 1.4-fold (0.15 log units) below what was measured, within the range that was stated.
By their numbers in this assay, from the lowest: compound 1; then compounds 3 and 2 (each within the scatter of the next).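

In this assay, the methyl on the saturated chain carbon, two bonds along the chain from an aromatic nitrogen, does not separate sec-butyl from pentan-3-yl (a 1.3-fold lower number from compound 2 to compound 3 (0.11 log units; within the scatter)). The 1-cyclopropylpropyl group of compound 1 still stands apart from pentan-3-yl (a 2.5-fold higher number from compound 1 to compound 3 (0.40 log units; beyond the scatter)), so at this position that group and the open-chain pentan-3-yl are distinguishable. No measurement offered here accounts for either step. The compounds shown leave open how a dicyclopropylmethyl or a methoxyethyl group on the same nitrogen would read.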